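From Benzofuranyl to Naphthyl on a Shared Core

This account rests on a few compounds, and the source may have more. Where it says the series, first, only, none or still open, it means among the compounds named here.

Of the compounds shown here, three built on one shared core have been measured in a functional assay on CHO cells for agonist activity at Free fatty acid receptor 1 (Homo sapiens), read by FLIPR and calcium flux, tested at 100 nM; on this read-out lower numbers stand for a weaker effect and higher numbers for a stronger effect at the one concentration tested. Compound 1 `Cc1nc(-c2ccsc2)sc1COc1ccc2c(c1)OCC2CC(=O)O` gives 56.5%. Compound 2 `Cc1nc(-c2ccc(Cl)s2)sc1COc1ccc2c(c1)OCC2CC(=O)O` gives 8.34%, and compound 3 `Cc1nc(-c2cc3ccccc3o2)sc1COc1ccc2c(c1)OCC2CC(=O)O` gives 14.8%. Compound 3 thus stands second highest of the three numbers: its nearest neighbour is compound 2, with the step of a number 6.5 percentage points higher from compound 2 to compound 3 (within the scatter) lying within the scatter, while its furthest is compound 1, the step of a number 41.7 percentage points lower from compound 1 to compound 3 (beyond the scatter) being large. Compound 4 `Cc1nc(-c2cccc3ccccc23)sc1COc1ccc2c(c1)OCC2CC(=O)O` has not yet been measured. It differs from compound 3 in one place: naphthalen-1-yl in place of 1-benzofuran-2-yl on an aromatic carbon. Within the data shown here, no measured step swaps one two-ring aromatic group for another. Among the measured compounds shown here, the steps that bear on the change are a number 48.2 percentage points lower from compound 1 to compound 2 (beyond the scatter) and a number 41.7 percentage points lower from compound 1 to compound 3 (beyond the scatter), both large drops when the thiophen-3-yl of compound 1 gave way to another group, and a number 6.5 percentage points higher from compound 2 to compound 3 (within the scatter), which shows two such other groups giving values within the scatter of each other. A step of no more than the scatter is therefore expected for a number 0.2 percentage points higher from compound 3 to compound 4 (within the scatter). Compound 4 is estimated at 15% in this assay, with a range from 3% to 40%.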

Compound 4, a percentage reported as activity, at one concentration (the size of the read-out at that concentration, not a potency): 8.53%
For compound 4 the middle estimate is 6.5 percentage points above the measured one, and the stated range covers the measured number.
By their numbers in this assay, from the lowest: compounds 2, 4 and 3 (each within the scatter of the next); then compound 1.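

In this assay the aromatic carbon next to the ring nitrogen and next to the ring sulfur now carries a group of two six-membered aromatic rings of carbon only, and the change shows as a number 6.3 percentage points lower from compound 3 to compound 4 (within the scatter) so a ring oxygen in this two-ring group makes no difference that can be read here. The comparison with a one-ring chlorinated group gives the same picture, as a number 0.2 percentage points higher from compound 2 to compound 4 (within the scatter) while a number 48 percentage points lower from compound 1 to compound 4 (beyond the scatter) puts naphthalen-1-yl with the other two replacements, leaving thiophen-3-yl alone apart among these four compounds. No measurement shown accounts for the gap between thiophen-3-yl and the other three groups.

The compounds shown leave open whether plain thiophen-2-yl, without the chlorine, or phenyl would stand with compound 1 or with the other three. Each reading comes from a single concentration, so these numbers show only a stronger or weaker effect at that concentration and leave open how the compounds would compare at any other.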